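Para Substituent Change on the Biaryl Core: Fluoro to Bromo

The compounds below may be only part of what the source reports. "The series", "measured", "known", "first", "only" and "open" are said of these compounds alone.

Measured compounds:
Compound 1, `COc1ccc(-c2cn3ccnc3c(-c3ccc4ncn(C5CCCCC5)c4c3)n2)cc1` — 78.8%
Compound 2, `Fc1ccc(-c2cn3ccnc3c(-c3ccc4ncn(C5CCCCC5)c4c3)n2)cc1` — 7.59%

In a functional assay on HCT-15 cells (Homo sapiens) for inhibition, read by sulforhodamine B assay, with a stated time of 48 h, tested at 10 uM (a higher number here means more inhibition at the concentration tested (going by the name of the read-out), a lower number less inhibition), compound 1 reaches 78.8%, while compound 2 gives 7.59%, the lowest of the two numbers. Among the measured compounds shown here, the single known step, a number 71.2 percentage points lower from compound 1 to compound 2 (beyond the scatter), separates them. Compound 3, `Brc1ccc(-c2cn3ccnc3c(-c3ccc4ncn(C5CCCCC5)c4c3)n2)cc1`, differs from compound 2 by bromo in place of fluoro on an aromatic carbon. For the measured compounds named here, no measured step swaps one halogen for another, so the known step offers only indirect guidance: it shows only that the number in this assay can be far lower after a change at this position, without saying where bromo will fall. Bromo is neither the methoxy of compound 1 nor the fluoro of compound 2, so a modest rise above compound 2 is expected, but with wide uncertainty. Compound 3 is therefore estimated at 25%, with a range from 3% to 65%. That corresponds to an expected step of a number 17.4 percentage points higher from compound 2 to compound 3 (beyond the scatter).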

Compound 3, a percentage reported as inhibition, at one concentration (the size of the read-out at that concentration, not a potency): 35.8%
Estimate against measurement, compound 3: 10.8 percentage points below; the measured number falls inside the stated range.
By their numbers in this assay, from the lowest: compound 2; then compound 3; then compound 1.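

In this assay, among the compounds shown here, the change from 4-fluorophenyl to 4-bromophenyl gives the first direct comparison of two halogens at this position (a number 28.2 percentage points higher from compound 2 to compound 3 (beyond the scatter)), so they are not interchangeable here. Bromo still does not restore the level seen with methoxy (a number 43 percentage points lower from compound 1 to compound 3 (beyond the scatter)), which places it in the middle of the three groups, with methoxy highest and fluoro lowest. No evidence at hand accounts for this order.

The compounds shown leave open where chloro would fall relative to fluoro and bromo, and whether an amine or a carboxylic acid on this aromatic carbon would reach the level of compound 1. They also leave open whether the same order of groups would hold with any other change to the shared core.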